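Shrinking the Ring on the Amide Nitrogen

The source may hold more compounds than are shown below. What is called first, only, known or untested is meant among the compounds shown, and "the series" means these compounds.

Measured so far:
compound 1, `CCN(CC)S(=O)(=O)c1ccc(S(=O)(=O)N2CCC[C@@H](C(=O)N3CCOCC3)C2)cc1`, 160 nM
compound 2, `CCN(CC)S(=O)(=O)c1ccc(S(=O)(=O)N2CCC[C@@H](C(=O)NC3CCOCC3)C2)cc1`, 1350 nM

In a functional assay on MIA PaCa-2 cells (Homo sapiens) for inhibition, read by MTT assay, with a stated time of 3 days (on this read-out higher numbers stand for weaker inhibition and lower numbers for stronger inhibition), compound 2 gives 1350 nM, the highest of the two numbers shown; the nearest is compound 1 with 160 nM. Going by the values given here, the only step on record, an 8.4-fold higher number from compound 1 to compound 2 (0.93 log units; beyond the scatter), concerns a different change at the carbonyl carbon and bears on the present step only loosely, showing that the group attached to the amide end can matter.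

Compound 3, `CCN(CC)S(=O)(=O)c1ccc(S(=O)(=O)N2CCC[C@@H](C(=O)N[C@H]3CCOC3)C2)cc1`, differs from compound 2 by oxolan-3-yl in place of oxan-4-yl on an amide-type nitrogen. Nothing measured tests a change between two saturated oxygen rings of neighbouring size, so no direction can be read from the data. The step is therefore expected to fall within the scatter, a 1.0-fold lower number from compound 2 to compound 3 (0.02 log units; within the scatter). On that basis compound 3 is estimated at 1300 nM, with a range from 450 nM to 3800 nM.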

Compound 3, half-maximal inhibitory concentration: 290 nM
Estimate against measurement, compound 3: 4.5-fold (0.65 log units) above, outside the stated range (below it).
By their numbers in this assay, from the lowest: compounds 1 and 3 (each within the scatter of the next); then compound 2.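

In this assay, the switch from oxan-4-yl to oxolan-3-yl on the amide-type nitrogen gives a 4.7-fold lower number from compound 2 to compound 3 (0.67 log units; beyond the scatter), so the choice between these two saturated oxygen rings clearly registers in this read-out. The earlier loss seen with compound 2 therefore does not apply to every ring attached through this nitrogen: a 1.8-fold higher number from compound 1 to compound 3 (0.26 log units; within the scatter), which leaves compound 1 and compound 3 indistinguishable here. No measurement shown explains why the smaller ring behaves differently.

From the compounds shown here alone, it remains open whether the ring oxygen matters, which a cyclopentyl group on the same nitrogen would test. Also unresolved are the role of the defined stereocentre in oxolan-3-yl, which its mirror-image form would address, and how a still smaller oxetan-3-yl ring would read.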